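Chloropurine benzyl chlorides: cytotoxicity on lung carcinoma cells

This account rests on a few compounds, and the source may have more. Where it says the series, first, only, none or still open, it means among the compounds named here.

Measured compounds:
- compound 1 `ClCc1ccccc1Cn1cnc2c(Cl)nc(Cl)nc21`: > 100000 nM
- compound 2 `ClCc1ccccc1Cn1cnc2c(Cl)ncnc21`: > 100000 nM
- compound 3 `ClCc1ccc(Cn2cnc3nc(Cl)nc(Cl)c32)cc1`: 79400 nM

Three compounds have been run in a functional assay on NCI-H460 cells (Homo sapiens) for cytotoxicity, read by sulforhodamine B assay, with a stated time of 48 h; a lower number here means that less compound is tolerated, a higher number that more compound is tolerated. For compound 1 the value > 100000 nM is a limit of the assay and not a number. For compound 2 the value > 100000 nM is likewise a limit. Compound 3 alone gives a number, 79400 nM, and it is the only one in the set that does. The step that the two limits leave unreadable from compound 1 to compound 2 is the change (hydrogen in place of chloro on an aromatic carbon); it cannot be read, because of the limit of > 100000 nM in this assay, at which 2 of the 3 values shown sit.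

Compound 3 and compound 1 carry the same atoms joined differently; the difference between the two cores is not broken down here.

Compound 4 `ClCc1ccc(Cn2cnc3ncnc(Cl)c32)cc1` has not yet been measured. It differs from compound 3 by hydrogen in place of chloro on an aromatic carbon, the same change as that from compound 1 to compound 2, with the place described in identical words. Among the measured compounds shown here, as the measured step of this change is unreadable, the only anchor is the number for compound 3, which already sits close to the limit of this assay. Compound 4 is therefore expected to give about 95000 nM, spanning 35000 nM to 250000 nM, with a real chance that only a limit is reported. The step of a 1.2-fold higher number from compound 3 to compound 4 (0.08 log units; within the scatter) is estimated to be small, resting on no readable measured step.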

Compound 4, concentration lethal to 50% of the cells: 17400 nM
The estimate for compound 4 lay 5.5-fold (0.74 log units) above the measured number; measured number below the stated range.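

In this assay, among the compounds shown here, hydrogen in place of chloro on an aromatic carbon gives a 4.6-fold lower number from compound 3 to compound 4 (0.66 log units; beyond the scatter), a modest step beyond the scatter, and it is the only reading of this change. The same change on the core of compound 1 cannot be read, because both compounds of that pair sit at a limit and give no number: the limit of > 100000 nM in this assay, at which 2 of the 4 values shown sit. The series therefore shows the change lowering the number on one core only; it neither supports nor contradicts a step of similar size or direction on the core of compound 1, and a single readable pair cannot establish that the change carries from one core to the other.

The compounds shown leave open whether the chloro that remains on the core of compound 4 can give way to an amine or a methoxy group, and how the number would respond. Also open, as far as these compounds go, is what the chloromethyl group contributes to the number, which a comparison with a hydroxymethyl or a plain methyl group in its place would address, as well as whether any such step would hold on the core of compound 1.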